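The compounds below may be only part of what the source reports. "The series", "measured", "known", "first", "only" and "open" are said of these compounds alone.

Of the compounds shown here, three have been measured so far in an assay on HEK293 cells for agonist activity at transient receptor potential cation channel subfamily M member 8 (Homo sapiens), read by fluorescence and calcium flux, with a stated time of 15 min; a lower number here means that less compound is needed, a higher number that more compound is needed for the effect. Compound 1 `CCN(Cc1ccc(C)s1)C(=O)COc1ccc(C)cc1` gives 178 nM in this assay. Compound 3 `CCN(Cc1cccs1)C(=O)CCc1ccc(C)cc1` gives 93 nM, and compound 2 `Cc1ccc(OCC(=O)N(Cc2cccs2)C2COC2)cc1` gives 23000 nM. Among these three numbers compound 1 stands second highest: the gap to compound 3 lies within the usual scatter of the method, so the two cannot be told apart, while the gap to compound 2 is far beyond it.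

The next compound, compound 4 `CCN(Cc1cncs1)C(=O)COc1ccc(C)cc1`, is not yet measured. It differs from compound 1 in one place: 1,3-thiazol-5-yl in place of 5-methylthiophen-2-yl on a saturated chain carbon bound to an amide-type nitrogen. Among the compounds with values here, no pair of measured compounds shares this change, so nothing directly anchors its effect; what can be said rests on compound 1 alone.

The expected step in this assay is a modest rise in the number, that is, somewhat more compound needed, on the edge of the scatter rather than clearly beyond it, as a 2.5-fold higher number from compound 1 to compound 4 (0.40 log units; beyond the scatter) expresses. Compound 4 is therefore estimated at 450 nM in this assay, with a range from 120 nM to 1800 nM.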

Compound 4, half-maximal effective concentration: 1100 nM
Beside the measured number, compound 4's estimate is 2.4-fold (0.39 log units) below it; measured number inside the range.
By their numbers in this assay, from the lowest: compounds 3 and 1 (each within the scatter of the next); then compound 4; then compound 2.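

In this assay, within the data shown here, putting 1,3-thiazol-5-yl in place of 5-methylthiophen-2-yl on a saturated chain carbon bound to an amide-type nitrogen gives a 6.2-fold higher number from compound 1 to compound 4 (0.79 log units; beyond the scatter) and so shows that the number responds to the ring at this place, which the earlier compounds could not show. This one change takes away the methyl and brings in a second ring hetero atom and a further hydrogen-bond acceptor by count, all at once. No measured property bears on this step, and the reason for it stays unknown.

The compounds shown leave open which of these differences carries the step, and a 2-methyl-1,3-thiazol-5-yl group would be one way to separate them. On these data alone, how a phenyl or a pyridin-3-yl ring would read at this place also remains open.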